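A few compounds are considered here, and "the series" means these few. Any claim that something is new, unique, unknown or untested is made for them only; others in the source may bear on it.

Measured compounds in a functional assay on MGC-803 cells (Homo sapiens) for inhibition, read by MTT assay, with a stated time of 72 h; a lower number here means a stronger inhibitor, a higher number a weaker inhibitor:
- compound 1 `Cc1cc(Nc2ccn(Cc3cccc4ccccc34)n2)n2nc(SCc3ccc(Br)cc3)nc2n1`: 3240 nM
- compound 2 `Cc1cc(Nc2cc(-c3ccccc3)[nH]n2)n2nc(SCc3ccc(C(F)(F)F)cc3)nc2n1`: 3520 nM

Compound 1 gives 3240 nM in this assay, and compound 2 gives 3520 nM; the gap between these two numbers lies within the scatter, so they cannot be told apart. For the measured compounds named here, compound 2 differs from compound 1 in more than one place, so no single step is recorded between them.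

Compound 3 `Cc1cc(Nc2ccn(Cc3csc4ccc(Cl)cc34)n2)n2nc(SCc3ccc(Br)cc3)nc2n1` is the unmeasured analogue of compound 1. The change is 5-chloro-1-benzothiophen-3-yl in place of naphthalen-1-yl on a saturated chain carbon bound to an aromatic nitrogen. The entering group carries one sulfur, one chlorine and one hydrogen-bond acceptor where the leaving group carries none. Going by the values given here, no measured pair shows how a change on this saturated chain carbon bound to an aromatic nitrogen moves the number, so the expectation rests on compound 1 alone. The step from compound 1 is expected to be small, a 1.1-fold lower number from compound 1 to compound 3 (0.03 log units; within the scatter), none beyond the scatter. Compound 3 is therefore estimated at 3000 nM, with a range from 1100 nM to 8500 nM.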

Compound 3, half-maximal inhibitory concentration: 1570 nM
For compound 3 the middle estimate is 1.9-fold (0.28 log units) above the measured one, and the stated range covers the measured number.
By their numbers in this assay, from the lowest: compound 3; then compounds 1 and 2 (each within the scatter of the next).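

In this assay, the position on a saturated chain carbon bound to an aromatic nitrogen now has its first readable step, a 2.1-fold lower number from compound 1 to compound 3 (0.31 log units; beyond the scatter), so the number does respond to a change at this place. The step is modest, and it shows that 5-chloro-1-benzothiophen-3-yl, with its five-membered aromatic ring holding a sulfur, can replace naphthalen-1-yl here without loss in this assay. No measurement on hand gives a reason for the step.

The sulfur-containing ring and the chlorine enter together, so their shares remain unseparated, and the plain 1-benzothiophen-3-yl group or a 5-fluoro-1-benzothiophen-3-yl group would bear on this. On these data alone, how an amine or a carboxylic acid carried on this saturated chain carbon would move the number also remains open.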